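A few compounds are considered here, and "the series" means these few. Any claim that something is new, unique, unknown or untested is made for them only; others in the source may bear on it.

Measured so far in an ADME assay on Vero cells (Chlorocebus sabaeus) for cytotoxicity; a lower number here means that less compound is tolerated, a higher number that more compound is tolerated:
- compound 1 `CN1CCN(CC(=O)Nc2ccc(-c3nc4cc(C(F)(F)F)ccc4n3C)cc2)CC1`: > 100000 nM
- compound 2 `O=C(CN1CCCCC1)Nc1ccc(-c2nc3ccccc3[nH]2)cc1`: > 100000 nM
- compound 3 `O=C(CCl)Nc1ccc(-c2nc3cc(C(F)(F)F)ccc3[nH]2)cc1`: 35000 nM

Compound 1 stands only at a limit of this assay: its value > 100000 nM is a limit, not a number. Compound 2 likewise gives only a limit in this assay. Among the measured compounds shown here, compound 3 is the one compound with a number, giving 35000 nM in this assay. For the measured compounds named here, of the three values shown, two sit at the limit of > 100000 nM in this assay, at which 2 of the 3 values shown sit, so the series as a whole is read as well tolerated by the cells, with compound 3 the only one to return a number.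

Compound 4 `Cn1c(-c2ccc(NC(=O)CN3CCCCC3)cc2)nc2cc(C(F)(F)F)ccc21` is not yet measured. It differs from compound 1 by piperidin-1-yl in place of 4-methylpiperazin-1-yl on a saturated chain carbon bound to a carbonyl carbon. Going by the values given here, no measured pair in this set differs in one place, so there is no measured step to lean on. Compound 2 carries the same piperidin-1-yl group on the chain and sits at a limit in this assay. Given that, the step of a number no higher from compound 1 to compound 4 (the limit leaves the size open) is expected to be none beyond the scatter, with compound 4 expected to report a limit rather than a number. Compound 4 is estimated at 100000 nM in this assay, with a range from 40000 nM to 300000 nM.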

Compound 4, half-maximal cytotoxic concentration: > 100000 nM
Compound 4 ended at the assay's limit (the forecaster's own chance of this, stated with the estimate: 70%); the middle value sits exactly at the limit.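

In this assay, compound 1 and compound 4 both give only a limit and not a number, so no step can be read for piperidin-1-yl in place of 4-methylpiperazin-1-yl. The compounds shown leave open whether these two groups differ at all in this read-out, with most of the series giving no number: the limit of > 100000 nM in this assay, at which 3 of the 4 values shown sit.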